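Chain extension on the shared core: compound 2 to compound 3

This account rests on a few compounds, and the source may have more. Where it says the series, first, only, none or still open, it means among the compounds named here.

Of the compounds shown here, two of the shared core have been measured in a physicochemical assay for lipophilicity; a lower number here means a more polar compound, a higher number a more lipophilic compound. Compound 1 `CCCCOc1ccc2[nH]c(-c3cccc(OC)c3)c(C3=C(Br)C(=O)NC3=O)c2c1` gives 3.46 in this assay. Compound 2 `CCc1ccc2[nH]c(-c3cccc(OC)c3)c(C3=C(Br)C(=O)NC3=O)c2c1` gives 3.35 in this assay. Among the measured compounds shown here, the only single-point step between them is a number 0.11 log units lower from compound 1 to compound 2 (within the scatter); compound 2 therefore holds the lower of the two numbers, with compound 1 the nearest at a gap within the scatter, so the two cannot be put in order.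

Compound 3 `CCCCCCc1ccc2[nH]c(-c3cccc(OC)c3)c(C3=C(Br)C(=O)NC3=O)c2c1` is not yet measured in this assay. It differs from compound 2 by butyl in place of hydrogen on a saturated chain carbon, two bonds along the chain from an aromatic carbon. For the measured compounds named here, no measured step adds to the chain at this place: a number 0.11 log units lower from compound 1 to compound 2 (within the scatter) exchanges one group for another and was within the scatter, so it gives no direct guide to the size of the present change. On the basis of butyl in place of hydrogen on a saturated chain carbon, two bonds along the chain from an aromatic carbon alone, a rise in this assay beyond the scatter is expected, and the expected step is a number 1.05 log units higher from compound 2 to compound 3 (beyond the scatter). For compound 3 the estimate in this assay is 4.4, expected to fall between 3.8 and 5.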

Compound 3, partition coefficient: 4.26
For compound 3 the middle estimate is 0.14 log units above the measured one; the range from low to high includes it.
By their numbers in this assay, from the lowest: compounds 2 and 1 (each within the scatter of the next); then compound 3.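

In this assay, among the compounds shown here, butyl in place of hydrogen on a saturated chain carbon, two bonds along the chain from an aromatic carbon, gives the first step to clear the scatter: a number 0.91 log units higher from compound 2 to compound 3 (beyond the scatter). Also clearing it is a number 0.80 log units higher from compound 1 to compound 3 (beyond the scatter), so this position now separates substituents, whereas ethyl and butoxy could not be put in order there and hexyl stands apart from both. Nothing measured here accounts for the size of either step.

With only ethyl and hexyl as plain carbon chains at this position, the compounds shown do not tell whether the number climbs steadily with chain length or levels off, and propyl or a longer chain such as octyl would settle that. For the compounds shown here, also open is whether an amine or a carboxylic acid in place of hexyl at this position would bring the number back towards the one compound 2 gives, 3.35.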